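A few compounds are considered here, and "the series" means these few. Any claim that something is new, unique, unknown or untested is made for them only; others in the source may bear on it.

Compound 1 `Cc1ccc(N2CCN(C(=O)Nc3ccc(C(F)(F)F)cc3)CC2)nn1` gives > 10000 nM in an assay on HEK293 cells for inhibition of transient receptor potential cation channel subfamily V member 1 (Homo sapiens), read by FLIPR (on this read-out lower numbers stand for stronger inhibition and higher numbers for weaker inhibition), which is a limit of the assay rather than a number.
Compound 2 `O=C(Nc1ccc(C(F)(F)F)cc1)N1CCN(c2cccnn2)CC1` gives > 10000 nM in this assay, again only a limit.
Compound 3 `O=C(Nc1nc2ccc(F)cc2s1)N1CCN(c2cccnn2)CC1` gives > 10000 nM in this assay, also a limit.

Compound 2 and compound 3 differ in more than one place, and the difference between the two cores is not broken down here. From compound 2 to compound 1 the change is methyl in place of hydrogen on an aromatic carbon, giving a step that the two limits leave unreadable from compound 2 to compound 1. Compound 4 `Cc1ccnnc1N1CCN(C(=O)Nc2nc3ccc(F)cc3s2)CC1`, not yet measured, carries the same kind of change on compound 3: methyl in place of hydrogen on an aromatic carbon. The place differs, though: in compound 1 the methyl sits next to the ring nitrogen and para to a large group, in compound 4 ortho to a large group and opposite the ring nitrogen.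

Because every measured value sits at the limit of > 10000 nM in this assay, at which 3 of the 3 values shown sit, no reading of this change exists, and compound 4 is expected to remain there as well, an estimated 20000 nM, a step that the limit leaves unreadable from compound 3 to compound 4.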

Compound 4, half-maximal inhibitory concentration: 6170 nM
Beside the measured number, compound 4's estimate is 3.2-fold (0.51 log units) above it; measured number inside the range.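

In this assay, methyl in place of hydrogen on an aromatic carbon gives an at least 1.6-fold lower number from compound 3 to compound 4 (0.20 log units; that floor lies within the scatter), so compound 4 has a real number, yet the change is not shown to exceed the scatter, and its true size stays unknown. This single step says nothing about whether the change carries from one core to another, since the methyl also sits at a different place in compound 1. The step from the other core cannot be read, because both of its ends are limits of the assay and not numbers: the limit of > 10000 nM in this assay, at which 3 of the 4 values shown sit.

From the compounds shown here alone, it remains open whether a methyl at the place it holds in compound 4 would give a readable value on the core of compound 2. Going by these compounds, it also remains open how an ethyl group or an amine at that same place would compare with methyl.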